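The compounds below may be only part of what the source reports. "The series", "measured", "known", "first", "only" and "open" are said of these compounds alone.

Measured compounds:
compound 1, `CCc1cccc(NC(=O)CN2CCC(c3cccc[n+]3[O-])CC2)c1`, 95 nM
compound 2, `Cc1cc(C)cc(NC(=O)CN2CCC(c3cccc[n+]3[O-])CC2)c1`, 52 nM
compound 3, `O=C(CN1CCC(c2cccc[n+]2[O-])CC1)Nc1cccc(F)c1`, 160 nM

In a functional assay on HEK293 cells for agonist activity at D(4) dopamine receptor (Homo sapiens), read by FLIPR (a lower number here means that less compound is needed, a higher number that more compound is needed for the effect), compound 3 holds the highest number of the three measured. Its nearest neighbour is compound 1, and the step of a 1.7-fold higher number from compound 1 to compound 3 (0.23 log units; within the scatter) stays within the scatter; the gap to compound 2, a 3.1-fold higher number from compound 2 to compound 3 (0.49 log units; beyond the scatter), lies beyond it.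

Compound 4, `CC(C)Oc1cccc(NC(=O)CN2CCC(c3cccc[n+]3[O-])CC2)c1`, carries the change (isopropoxy in place of fluoro on an aromatic carbon). For the measured compounds named here, two measured steps bear on it. The step of a 1.7-fold higher number from compound 1 to compound 3 (0.23 log units; within the scatter), read in reverse, shows that a larger group in place of fluoro went with a somewhat lower number, though within the scatter. The step of a 3.1-fold higher number from compound 2 to compound 3 (0.49 log units; beyond the scatter) shows a modest rise when fluoro replaced the dimethyl pattern. Both point the same way: a group larger than fluoro at this position tends toward a lower number, but only by a small margin. For compound 4 a lowering of about the size of a 1.8-fold lower number from compound 3 to compound 4 (0.25 log units; within the scatter) is therefore expected, probably inside the scatter. The estimate for compound 4 in this assay is 90 nM, with a range from 35 nM to 250 nM.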

Compound 4, half-maximal effective concentration: 555 nM
Beside the measured number, compound 4's estimate is 6.2-fold (0.79 log units) below it; measured number outside the range, above it.
By their numbers in this assay, from the lowest: compounds 2, 1 and 3 (each within the scatter of the next, the first and the last beyond it); then compound 4.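

In this assay, isopropoxy in place of fluoro on the aromatic carbon gave a 3.5-fold higher number from compound 3 to compound 4 (0.54 log units; beyond the scatter), and isopropoxy in place of ethyl gave a 5.8-fold higher number from compound 1 to compound 4 (0.77 log units; beyond the scatter). Fluoro and ethyl had stayed within the scatter of each other, so this position had shown no clear response until isopropoxy, and among these three groups the larger count of heavy atoms does not go with a lower number. Nothing available explains the rise.

The compounds shown leave open whether the rise goes with the oxygen of isopropoxy or with its carbons; a methoxy group and an isopropyl group at this place would separate the two. From the compounds shown here alone, how an amine or a carboxylic acid at this place would read also remains open.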